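A Ring Swap on the Thiocarbonyl Carbon

The compounds below may be only part of what the source reports. "The series", "measured", "known", "first", "only" and "open" are said of these compounds alone.

Measured compounds:
compound 1 `Cc1cccc(/C(N)=N/NC(=S)N2CCCCC2)n1`: 63.2%
compound 2 `Cc1ccnc(/C(N)=N/NC(=S)N2CCCCC2)c1`: 69.5%
compound 3 `N/C(=N\NC(=S)N1CCN(c2ccccn2)CC1)c1ccccn1`: 73.7%

In a functional assay on A-375 cells (Homo sapiens) for cytotoxicity, read by MTT assay, with a stated time of 72 h, tested at 3 uM (on this read-out lower numbers stand for less inhibition of growth and higher numbers for more inhibition of growth at the one concentration tested), compound 1 gives 63.2%, the lowest of the three numbers. Among the measured compounds shown here, compound 2 gives 69.5%, a value that sits within the scatter of the one for compound 1, so the two cannot be told apart. Compound 3 gives 73.7%, which lies beyond the scatter above the value of compound 1.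

Compound 4 `Cc1cccc(/C(N)=N/NC(=S)N2CCOCC2)n1` has not yet been measured in this assay. It differs from compound 1 in one place: morpholin-4-yl in place of piperidin-1-yl on a thiocarbonyl carbon. For the measured compounds named here, no measured pair shows this change, so the data give no step to lean on. The account therefore expects, for the step from compound 1 to compound 4, a number 5.2 percentage points lower from compound 1 to compound 4 (within the scatter), a shift that is estimated to stay within the scatter, with a slight downward lean. Compound 4 is estimated to give 58%, with a range from 40% to 75%.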

Compound 4, percent growth inhibition at one concentration: 34.7%
Compound 4: the middle estimate sits 23.3 percentage points above what was measured, and the stated range ends above it.
By their numbers in this assay, from the lowest: compound 4; then compounds 1, 2 and 3 (each within the scatter of the next, the first and the last beyond it).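

In this assay, morpholin-4-yl in place of piperidin-1-yl on a thiocarbonyl carbon gives a number 28.5 percentage points lower from compound 1 to compound 4 (beyond the scatter) on the core of compound 1. This position is therefore not indifferent to the ring it carries: two six-membered non-aromatic rings with the same count of heavy atoms, one with a ring oxygen and a hydrogen-bond acceptor and the other without, can be told apart in this read-out. Nothing measured here accounts for the drop.

Going by these compounds, whether the same fall would follow a 4-methylpiperazin-1-yl ring or an open-chain dimethylamino group on this carbon remains open. The compounds shown also leave open whether the step would keep its size on the core of compound 2.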